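This account rests on a few compounds, and the source may have more. Where it says the series, first, only, none or still open, it means among the compounds named here.

Working notes on the series, read in a functional assay on the whole organism with Rattus norvegicus as the target; a lower number here means that less compound is needed, a higher number that more compound is needed for the effect. Compound 1 `CCOC(=O)C(=O)Nc1nc(-c2ccc(OC)cc2)cs1` gives about 10 mg/kg. Compound 2 `CCOC(=O)C(=O)Nc1nc(-c2ccc(OC)cc2OC)cs1` is known only as a limit, > 30 mg/kg. Within the data shown here, compound 3 `CCOC(=O)C(=O)Nc1nc(-c2ccc(OC)cc2O)cs1` gives about 1 mg/kg, the lowest number so far, with compound 1 the nearest measured value.

Next comes compound 4 `CCOC(=O)C(=O)Nc1nc(-c2ccc(-c3ccccc3)cc2O)cs1`, with phenyl in place of methoxy on an aromatic carbon. Among the measured compounds shown here, no measured step changes this methoxy group, so the evidence is indirect. Hydroxy in place of hydrogen gave a 10-fold lower number from compound 1 to compound 3 (1.00 log units; beyond the scatter), while methoxy in place of hydrogen gave an at least 3.0-fold higher number from compound 1 to compound 2 (0.47 log units; beyond the scatter). Removing the methyl from that oxygen gave an at least 30-fold lower number from compound 2 to compound 3 (1.47 log units; beyond the scatter). These steps show that this series can respond strongly to a single ring substituent in this assay. As far as these compounds go, the hydroxy group stays in compound 4, but the phenyl group is untested, so a modest rise is expected, with the direction uncertain. The expected step is a 3.0-fold higher number from compound 3 to compound 4 (0.48 log units; beyond the scatter). Compound 4 is estimated at 3 mg/kg, with an expected range of 0.5 mg/kg to 20 mg/kg.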

Compound 4, dose for half-maximal effect: > 10 mg/kg
Compound 4: no number, only a limit; the forecaster's own chance of this, stated with the estimate: 15%; at least 3.3-fold (0.52 log units) between middle value and limit.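

Among these compounds, the earlier steps all kept methoxy at this position, so compound 4 gives the first reading of a change on this aromatic carbon, meta to a hydroxy group. Phenyl in place of methoxy gives an at least 10-fold higher number from compound 3 to compound 4 (1.00 log units; beyond the scatter), so the hydroxy group retained from compound 3 does not by itself preserve the low number when this position changes. The result for compound 4 in this assay is a limit and not a number, so the full size of the step remains unknown: the limit of > 10 mg/kg in this assay, at which 1 of the 4 values shown sits.

With only methoxy and phenyl compared here, the effects of removing the oxygen and of adding the aromatic ring cannot be separated. As far as these compounds go, it remains open whether methyl, ethoxy, benzyloxy or an amine at this position would keep the low number of compound 3.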